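The source may hold more compounds than are shown below. What is called first, only, known or untested is meant among the compounds shown, and "the series" means these compounds.

In a functional assay on U-87MG ATCC cells for inhibition, with U-87 MG (Homo sapiens) as the target, read by MTT assay, with a stated time of 48 h (on this read-out higher numbers stand for weaker inhibition and lower numbers for stronger inhibition), compound 1 (`CS(=O)(=O)c1ccc(-c2nc3ccccn3c2Sc2ccccc2)cc1`) gives 77200 nM and compound 2 (`C(=C/c1nc2ccccn2c1Sc1ccccc1)\c1ccccc1`) stands at 59200 nM within the usual scatter of compound 1. Going by the values given here, the two numbers therefore cannot be ranked, and compound 2 sits level with the only other measured compound. Compound 3 (`Clc1ccc(-c2nc3ccccn3c2Sc2ccccc2)cc1`) has not yet been measured. It differs from compound 2 by 4-chlorophenyl in place of 2-phenylethenyl on an aromatic carbon. Among the compounds with values here, no measured pair differing in one place is available to guide this exchange, and the two known numbers lie close together, so no shift beyond the scatter is expected. In this assay the expected step is a 1.0-fold higher number from compound 2 to compound 3 (0.01 log units; within the scatter) and it stays within the scatter, with no firm direction. For compound 3 the estimated value is 60000 nM with an expected range from 25000 nM to 120000 nM in repeated measurements.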

Compound 3, half-maximal inhibitory concentration: 30200 nM
For compound 3 the middle estimate is 2.0-fold (0.30 log units) above the measured one; the range from low to high includes it.
By their numbers in this assay, from the lowest: compounds 3, 2 and 1 (each within the scatter of the next, the first and the last beyond it).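

In this assay, the exchange at the aromatic carbon of the five-membered ring gives a 2.0-fold lower number from compound 2 to compound 3 (0.29 log units; within the scatter), so 4-chlorophenyl and 2-phenylethenyl cannot be told apart at this position. A step beyond the scatter does appear with chloro in place of methylsulfonyl on an aromatic carbon, which gives a 2.6-fold lower number from compound 1 to compound 3 (0.41 log units; beyond the scatter), a modest step that shows this single exchange can shift the number in this assay. Nothing available explains either step.

Going by these compounds, what a methoxy group or an amine would do in place of chloro stays open, as does any exchange of the phenylsulfanyl group shared by all three compounds. It also remains open whether the modest step would hold in other cells, as only this one read-out is shown.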